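Methyl for Fluoro: Estimating Compound 4

The source may report more compounds than this note shows. Statements on the series, on what has been measured and on what is new or still open speak of the compounds shown alone.

Compound 1 `COc1cc(-n2cnc3ccc(-c4cccc(F)c4)cc32)cc(OC)c1OC` — 2490 nM
Compound 2 `COc1cc(-n2cnc3ccc(-c4ccc(Cl)cc4Cl)cc32)cc(OC)c1OC` — > 10000 nM
Compound 3 `COc1cc(-n2cnc3ccc(-c4cccc(C)c4)cc32)cc(OC)c1OC` — 1240 nM

All three were tested in a functional assay on SGC-7901 cells (Homo sapiens) for antiproliferative activity, read by MTT assay, with a stated time of 72 h; on this read-out lower numbers stand for stronger inhibition and higher numbers for weaker inhibition. Compound 1 and compound 3 sit within the scatter of each other, the step of a 2.0-fold lower number from compound 1 to compound 3 (0.30 log units; within the scatter) being methyl in place of fluoro on an aromatic carbon. Compound 2 stands at a limit of the assay, not a number (the limit of > 10000 nM in this assay, at which 1 of the 3 values shown sits).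

Compound 4 `COc1cc(-n2cnc3ccc(-c4ccc(C)cc4)cc32)cc(OC)c1OC` is not yet measured. It differs from compound 1 by 4-methylphenyl in place of 3-fluorophenyl on an aromatic carbon. Within the data shown here, the one measured step that bears on it is a 2.0-fold lower number from compound 1 to compound 3 (0.30 log units; within the scatter), the same swap at another place on the ring, which stayed within the scatter; an at least 4.0-fold higher number from compound 1 to compound 2 (0.60 log units; beyond the scatter) concerns a different change. Compound 4 is therefore expected to give about 2000 nM, between 700 nM and 6000 nM. For compound 4 this means an expected step of a 1.2-fold lower number from compound 1 to compound 4 (0.10 log units; within the scatter), within the scatter.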

Compound 4, half-maximal inhibitory concentration: 200 nM
The estimate for compound 4 lay 10-fold (1.00 log units) above the measured number; the whole stated range lies above it.
By their numbers in this assay, from the lowest: compound 4; then compounds 3 and 1 (each within the scatter of the next). At a limit, above all of these: compound 2.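

Among these compounds, the step of a 6.2-fold lower number from compound 3 to compound 4 (0.79 log units; beyond the scatter) comes from 4-methylphenyl in place of 3-methylphenyl alone, so where the methyl sits on this ring matters, which the earlier compounds did not show. The step of a 12-fold lower number from compound 1 to compound 4 (1.10 log units; beyond the scatter) is larger, but it changes both the group and its place on the ring. Compound 2 stands at a limit of the assay, not a number, so the step of an at least 50-fold lower number from compound 2 to compound 4 (1.69 log units; beyond the scatter) is only a bound.

As far as these compounds go, whether 4-ethylphenyl, with its longer chain, or 4-aminophenyl, with its amine, would keep this gain stays open. So does whether 4-fluorophenyl would match the methyl.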